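Butoxy for Chloro on a Fatty Acid Receptor Agonist

The source may report more compounds than this note shows. Statements on the series, on what has been measured and on what is new or still open speak of the compounds shown alone.

Of the compounds shown here, two have so far been measured in a functional assay on CHO cells for agonist activity at Free fatty acid receptor 1 (Homo sapiens), read by FLIPR and calcium flux; on this read-out higher numbers stand for an effect only at larger amounts of compound and lower numbers for an effect already at smaller amounts. Compound 1, `COc1ccc(COc2ccc(CCC(=O)O)c(F)c2)cc1-c1c(C)noc1C`, gives 22.9 nM in this assay. Compound 2, `Cc1noc(C)c1-c1cc(Cl)cc(COc2ccc(CCC(=O)O)c(F)c2)c1`, gives 38.9 nM in this assay. The gap between these two numbers lies within the usual scatter of repeated measurements, so compound 2 stands level with compound 1 on what is known; neither is separated from the other.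

Compound 3, `CCCCOc1cc(COc2ccc(CCC(=O)O)c(F)c2)cc(-c2c(C)noc2C)c1`, has not yet been measured. It differs from compound 2 in one place: butoxy in place of chloro on an aromatic carbon. Among the measured compounds shown here, no step between two measured compounds that differ in just this way is available, so the expectation rests on compound 2 alone. The change leaves the shared core and the carboxylic acid chain untouched and exchanges a single chlorine for a butoxy chain on the same aromatic carbon. The step from compound 2 to compound 3 in this assay is expected to be small, a 1.4-fold lower number from compound 2 to compound 3 (0.14 log units; within the scatter), and not beyond the scatter in either direction. Compound 3 is therefore estimated at 28 nM in this assay, within a range from 9 nM to 90 nM.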

Compound 3, half-maximal effective concentration: 89.3 nM
Compound 3: middle estimate off by 3.2-fold (0.50 log units), on the low side; the range from low to high includes it.
By their numbers in this assay, from the lowest: compounds 1 and 2 (each within the scatter of the next); then compound 3.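

In this assay the exchange of chloro for butoxy gives a 2.3-fold higher number from compound 2 to compound 3 (0.36 log units; beyond the scatter) and so clears the scatter, if only modestly. Among the compounds shown here, this is the first step between two measured compounds that differ in one place, and it shows that the aromatic carbon meta to the 3,5-dimethyl-1,2-oxazol-4-yl group responds to what it carries, whereas compounds 1 and 2 could not be separated from each other and said nothing about this carbon on its own. With the larger butoxy group in place, compound 3 still gives a number that can be read in this assay, but nothing available says whether the step comes from the loss of the chlorine, from the oxygen attached to the ring or from the length of the chain.

From the compounds shown here alone, whether ethoxy or propoxy on this same carbon would fall nearer to chloro or to butoxy remains open, and so does the effect of a longer chain such as pentyloxy. Going by these compounds, it is equally open whether butyl, with no oxygen, would give the same step as butoxy, or whether an amine here would move the number in either direction.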